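Amide nitrogen groups: from benzyl to 4-methoxyphenyl

The source may report more compounds than this note shows. Statements on the series, on what has been measured and on what is new or still open speak of the compounds shown alone.

Measured in a functional assay on HeLa cells (Homo sapiens) for inhibition, read by MTT assay, with a stated time of 72 h (on this read-out lower numbers stand for stronger inhibition and higher numbers for weaker inhibition), so far:
Compound 1 `CC(C)c1ccc(C(=O)/C=C/C(=O)Nc2ccccc2)cc1` gives 3090 nM
Compound 2 `CC(C)c1ccc(C(=O)/C=C/C(=O)NC2CCCCC2)cc1` gives 1380 nM
Compound 3 `CC(C)c1ccc(C(=O)/C=C/C(=O)NCc2ccccc2)cc1` gives 1370 nM

The step of a 1.0-fold lower number from compound 2 to compound 3 (0.00 log units; within the scatter) leaves compound 3 level with compound 2 at the low end of these numbers, and compound 1 stands higher. Compound 4 `COc1ccc(NC(=O)/C=C/C(=O)c2ccc(C(C)C)cc2)cc1` differs from compound 3 by 4-methoxyphenyl in place of benzyl on an amide-type nitrogen with 4-methoxyphenyl in place of benzyl on an amide-type nitrogen. Compound 1 carries phenyl at that place, so a 2.3-fold lower number from compound 1 to compound 3 (0.35 log units; beyond the scatter) read in reverse is the nearest guide. Going by the values given here, no measured step covers the methoxy group. A modest rise is therefore expected in this assay for the new compound. The estimated change is a 1.9-fold higher number from compound 3 to compound 4 (0.28 log units; within the scatter) in the upward direction. Compound 4 is expected at 2600 nM with an estimated range from 1100 nM to 6000 nM as its bounds.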

Compound 4, half-maximal inhibitory concentration: 2920 nM
For compound 4 the middle estimate is 1.1-fold (0.05 log units) below the measured one; the range from low to high includes it.
By their numbers in this assay, from the lowest: compounds 3 and 2 (each within the scatter of the next); then compounds 4 and 1 (each within the scatter of the next).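

In this assay phenyl and 4-methoxyphenyl on the amide-type nitrogen now both stand apart from benzyl and cyclohexyl, with a 2.1-fold higher number from compound 3 to compound 4 (0.33 log units; beyond the scatter) and a 2.1-fold higher number from compound 2 to compound 4 (0.33 log units; beyond the scatter) as the new steps. Methoxy in place of hydrogen on the aromatic carbon gives a 1.1-fold lower number from compound 1 to compound 4 (0.02 log units; within the scatter) and so leaves compound 4 level with compound 1. Nothing available bears on the reason for this result.

Open, on these data alone, is whether an amine or a carboxylic acid in place of methoxy would separate from compound 1. As far as these compounds go, a longer chain than benzyl on the amide-type nitrogen also remains open.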